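Adding Trifluoromethyl to the Benzamide of Compound 3

The compounds below may be only part of what the source reports. "The series", "measured", "known", "first", "only" and "open" are said of these compounds alone.

Compound 1 `NC(=O)c1c(NC(=O)c2ccc(C(F)(F)F)cc2)sc2c1CCN(Cc1ccc(Cl)cc1)C2`: > 50000 nM
Compound 2 `NC(=O)c1c(NC(=O)c2ccccc2Cl)sc2c1CCN(C(=S)Nc1ccccc1-c1ccccc1)C2`: 25800 nM
Compound 3 `NC(=O)c1c(NC(=O)c2ccccc2)sc2c1CCN(C(=S)Nc1ccccc1Cl)C2`: 11800 nM

All three compounds share one core and were tested in a functional assay on MKN-74 cells (Homo sapiens) for antiproliferative activity, with a stated time of 24 h; a higher number here means a weaker inhibitor, a lower number a stronger inhibitor. Compound 1 gives > 50000 nM, which is a limit of the assay rather than a number; of the three values one sits there (the limit of > 50000 nM in this assay, at which 1 of the 3 values shown sits). Compound 2 gives 25800 nM. Compound 3 gives 11800 nM, the lowest of the two numbers, and its gap to compound 2 lies beyond the usual scatter. Compound 2 and compound 3 differ in two places at once, so their values show only that both are weak inhibitors.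

Compound 4 `NC(=O)c1c(NC(=O)c2ccccc2C(F)(F)F)sc2c1CCN(C(=S)Nc1ccccc1Cl)C2` has not yet been measured. It differs from compound 3 in one place: trifluoromethyl in place of hydrogen on an aromatic carbon. A trifluoromethyl also sits on compound 1, but on another ring, so no step can be read from it. No single change between measured compounds is known here, so the step is estimated rather than read; it is expected to be a 1.3-fold higher number from compound 3 to compound 4 (0.10 log units; within the scatter), small and not clearly beyond the scatter. Compound 4 is expected at 15000 nM, with a range from 5000 nM to 45000 nM.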

Compound 4, half-maximal inhibitory concentration: 21900 nM
The estimate for compound 4 lay 1.5-fold (0.16 log units) below the measured number, within the range that was stated.
By their numbers in this assay, from the lowest: compounds 3, 4 and 2 (each within the scatter of the next, the first and the last beyond it). At a limit, above all of these: compound 1.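

In this assay, trifluoromethyl in place of hydrogen on an aromatic carbon, ortho to a large group, gives a 1.9-fold higher number from compound 3 to compound 4 (0.27 log units; within the scatter). This is the first single change that can be read among these compounds, and it shows that compound 3 and compound 4 cannot be told apart, so this position accepts trifluoromethyl without a difference beyond the scatter. Nothing measured here bears on the reason for this result.

As far as these compounds go, only hydrogen and trifluoromethyl can be compared at this position, so the effect of a different group there, such as an amine or a carboxylic acid, remains open. From the compounds shown here alone, whether any group at this position could give a clearly stronger inhibitor than compound 3 also remains open.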